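The source may report more compounds than this note shows. Statements on the series, on what has been measured and on what is new or still open speak of the compounds shown alone.

Compound 1 `CCC(CC)/N=C(\NC#N)Nc1ccncc1` was tested in a functional assay on the whole organism (blood, strain Wistar-Okamoto) with Rattus norvegicus as the target, with a stated time of 5 days (a higher number here means that more compound is needed for the effect, a lower number that less compound is needed), and in that assay compound 1 gave 2.5 mg/kg. Of the two compounds measured, compound 1 shows the lowest number; the other, compound 2 `CC(C)CCCC(C)N/C(=N\C#N)Nc1ccncc1`, gave 50 mg/kg in this assay, a gap that lies beyond the scatter of repeated measurement. Within the data shown here, the two compounds differ in several places along the chain attached to the shared core, so no single step between them can be read off.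

Compound 3 `CCC(/N=C(\NC#N)Nc1ccncc1)C(C)C` has not yet been measured. It differs from compound 1 by one change: methyl in place of hydrogen on a saturated chain carbon bound to two saturated chain carbons. Seen one bond further out, an ethyl becomes an isopropyl, and the pentan-3-yl chain becomes a 1-isopropylpropyl chain.

Among the measured compounds shown here, no measured pair isolates this change. For the measured compounds named here, the only comparison available, compound 2 with its longer chain, gave the higher dose. On that basis compound 3 is expected to need a somewhat higher dose than compound 1, and the step of a 2.0-fold higher number from compound 1 to compound 3 (0.30 log units; within the scatter) is expected to be small, possibly within the scatter. The estimate for compound 3 is 5 mg/kg, with a range from 2 mg/kg to 15 mg/kg.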

Compound 3, minimum effective dose: 5 mg/kg
The estimate for compound 3 equals the measured number at the digits printed, and the stated range covers the measured number.
By their numbers in this assay, from the lowest: compounds 1 and 3 (each within the scatter of the next); then compound 2.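

In this assay, among these compounds, methyl in place of hydrogen on a saturated chain carbon bound to two saturated chain carbons gives a 2.0-fold higher number from compound 1 to compound 3 (0.30 log units; within the scatter), the first single change whose size can be read on its own. Turning an ethyl into an isopropyl, and so pentan-3-yl into 1-isopropylpropyl, thus leaves the minimum effective dose indistinguishable from that of the parent within the scatter of repeated measurement, and this one added carbon at this position cannot be said to alter the result. No measurement offered here bears on what lies behind this outcome.

On these data alone, whether this place on the chain would accept more than one methyl, such as a tert-butyl group, or a different kind of group, such as a hydroxyl, an amine or a phenyl ring, remains open. Steps from compound 2 to the other two compounds cannot be read, since it differs from them in more than one place, so the effect of a longer chain on its own also remains unsettled.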